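The source may report more compounds than this note shows. Statements on the series, on what has been measured and on what is new or still open speak of the compounds shown alone.

Working notes on the series. For the measured compounds named here, in an assay on membranes from brain for displacement of a labelled ligand from adenosine receptor A1 (Rattus norvegicus), read by radioligand binding (a higher number here means a weaker inhibitor, a lower number a stronger inhibitor), compound 1 `COc1ccc2c(c1)C/C(=C\c1ccc(O)c(O)c1)C2=O` gives 3280 nM, the only definite number in the set. Compound 2 `COc1cc(OC)c(OC)cc1/C=C1\Cc2c(OC)cccc2C1=O` is reported in this assay only as a limit, > 100000 nM. Compound 3 `COc1cccc2c1C/C(=C\c1ccc(N(C)C)cc1)C2=O` likewise reaches only a limit in this assay, > 100000 nM. Thus compound 1 is the sole compound with a measured value, and the limit of > 100000 nM in this assay, at which 2 of the 3 values shown sit, marks where the other two sit. Compound 4 `COc1cc2c(cc1OC)C(=O)/C(=C/c1ccc(O)c(O)c1)C2` has not yet been measured in this assay. Compound 4 differs from compound 1 by methoxy in place of hydrogen on an aromatic carbon. Going by the values given here, no measured pair shows the effect of a comparable change, so the step is uncertain. The step from compound 1 to compound 4 is expected to be small and toward weaker binding, about a 1.8-fold higher number from compound 1 to compound 4 (0.26 log units; within the scatter). Compound 4 is therefore estimated at 6000 nM, with a range from 1500 nM to 25000 nM in this assay.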

Compound 4, inhibition constant: 4290 nM
Beside the measured number, compound 4's estimate is 1.4-fold (0.15 log units) above it; measured number inside the range.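

In this assay the series now has its first pair differing in one place, with a 1.3-fold higher number from compound 1 to compound 4 (0.12 log units; within the scatter) for methoxy in place of hydrogen on an aromatic carbon, ortho to a methoxy group. This position of the shared core therefore takes a methoxy with the two values within the scatter of each other. Compound 2 and compound 3 stand only as limits, so no step to them can be read: the limit of > 100000 nM in this assay, at which 2 of the 4 values shown sit.

Open, as far as these compounds go, is whether an amine, a carboxylic acid or a longer chain at this position would also stay within the scatter. One pair cannot show whether the same holds on a core without the two hydroxyl groups of compound 4.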